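Configuration change from compound 3 to compound 4

The source may hold more compounds than are shown below. What is called first, only, known or untested is meant among the compounds shown, and "the series" means these compounds.

In a functional assay on HOS cells (Homo sapiens) for antiproliferative activity, read by sulforhodamine B assay (a lower number here means a stronger inhibitor of growth, a higher number a weaker inhibitor of growth), compound 1 (`O[C@H]1CO[C@H](COCc2ccccc2)[C@@H](OCc2ccccc2)[C@@H]1OCc1ccccc1`) gives 37900 nM. Compound 2 (`CCC[C@@H]1O[C@H](COCc2ccccc2)[C@@H](OCc2ccccc2)[C@H](OCc2ccccc2)[C@H]1O`) gives 38600 nM, and compound 3 (`CCC[C@H]1O[C@H](COCc2ccccc2)[C@@H](OCc2ccccc2)[C@H](OCc2ccccc2)[C@H]1O`) gives 23600 nM. Compound 3 stands level with the other two, as a 1.6-fold lower number from compound 1 to compound 3 (0.21 log units; within the scatter) and a 1.6-fold lower number from compound 2 to compound 3 (0.21 log units; within the scatter) show. Adding the propyl group to compound 1 also leaves the number within the scatter, with a 1.0-fold higher number from compound 1 to compound 2 (0.01 log units; within the scatter).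

Compound 4 (`CCC[C@@H]1O[C@H](COCc2ccccc2)[C@@H](OCc2ccccc2)[C@H](OCc2ccccc2)[C@@H]1O`) is still unmeasured. It has the same atoms and bonds as compound 3, and the change is the two compounds have the same atoms and bonds and differ only in configuration as drawn: 2 of 5 stereo elements differ; a stereocentre at a saturated ring carbon is drawn R in compound 3 and S in compound 4; a stereocentre at a saturated ring carbon is drawn S in compound 3 and R in compound 4. Nothing leaves and nothing enters.

Going by the values given here, the closest precedent is a 1.6-fold lower number from compound 2 to compound 3 (0.21 log units; within the scatter), a comparison resting on (the fact that compounds 2 and 3 differ only in the configuration as drawn). That step alters one stereocentre at a saturated ring carbon, whereas the coming step alters two, so the precedent is only partial. Each of the three measured steps is small and within the scatter, so no step beyond the scatter is expected in this assay, and no direction is favoured with any confidence.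

The estimate amounts to a 1.2-fold higher number from compound 3 to compound 4 (0.07 log units; within the scatter), an expected step within the scatter.

For compound 4 the expected value is 28000 nM, with an estimated range of 14000 nM to 55000 nM.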

Compound 4, concentration for 50% growth inhibition: > 50000 nM
Compound 4 gave a limit, no number; the forecaster's own chance of this, stated with the estimate: 8%; at least 1.7-fold (0.25 log units) between middle value and limit.
By their numbers in this assay, from the lowest: compounds 3, 1 and 2 (each within the scatter of the next). At a limit, above all of these: compound 4.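

In this assay compound 4 gives > 50000 nM, which is a limit of the assay and not a number. Even so, the configuration pair now registers: an at least 2.1-fold higher number from compound 3 to compound 4 (0.32 log units; beyond the scatter) is the first step in the series beyond the scatter, and with no atom or bond changed, only configuration can account for it: the fact that compounds 3 and 4 differ only in the configuration as drawn The single-centre comparison remains unresolved, as an at least 1.2-fold higher number from compound 2 to compound 4 (0.11 log units; that floor lies within the scatter) has a floor that does not separate the two compounds, just as a 1.6-fold lower number from compound 2 to compound 3 (0.21 log units; within the scatter) did not separate the earlier pair.

The compounds shown leave open whether one stereocentre carries the step or both are needed: compound 2 differs from compound 3 at one centre and from compound 4 at the other, and neither single change is resolved beyond the scatter. Also open, from the compounds shown here alone, is how a longer chain such as butyl in place of propyl, or an amine in place of the hydroxyl, would read in either configuration.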